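Swapping a five-membered ring for a four-membered one

The source may report more compounds than this note shows. Statements on the series, on what has been measured and on what is new or still open speak of the compounds shown alone.

In an ADME assay on MT4 cells (Homo sapiens) for cytotoxicity, read by MTT assay, with a stated time of 5 days (a higher number here means that more compound is tolerated, a lower number that less compound is tolerated), compound 1 `Cc1cc(C)cc(S(=O)(=O)c2c(C(=O)N[C@@H]3CCN(Cc4ccccc4C#N)C3)[nH]c3ccc(Cl)cc23)c1` reads >= 186000 nM, which is a limit of the assay and not a number (the limit of >= 186000 nM in this assay, at which 1 of the 2 values shown sits). Within the data shown here, compound 2 `Cc1cc(C)cc(S(=O)(=O)c2c(C(=O)N[C@@H]3CCN(CC(N)=O)C3)[nH]c3ccc(Cl)cc23)c1` gives 31000 nM, the only true number so far. Compound 3 `Cc1cc(C)cc(S(=O)(=O)c2c(C(=O)NC3CN(CC(N)=O)C3)[nH]c3ccc(Cl)cc23)c1` differs from compound 2 by one change 1-(carbamoylmethyl)azetidin-3-yl in place of 1-(carbamoylmethyl)pyrrolidin-3-yl on an amide-type nitrogen. Among the measured compounds shown here, the sole measured step, an at least 6.0-fold lower number from compound 1 to compound 2 (0.77 log units; beyond the scatter), exchanged 2-cyanophenyl for carbamoyl, and it bears on this change only indirectly. For the measured compounds named here, compound 3 keeps that carbamoyl, and no measured step alters the ring, so the reading for compound 2 at 31000 nM is the best guide. The expected change is small, a 1.3-fold higher number from compound 2 to compound 3 (0.11 log units; within the scatter), and none beyond the scatter is expected. For compound 3 the estimated value is 40000 nM, with an expected range from 15000 nM to 110000 nM.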

Compound 3, half-maximal cytotoxic concentration: 25500 nM
Estimate against measurement, compound 3: 1.6-fold (0.20 log units) above, within the range that was stated.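

In this assay, among these compounds, the change from 1-(carbamoylmethyl)pyrrolidin-3-yl to 1-(carbamoylmethyl)azetidin-3-yl on the amide-type nitrogen is the first measured step that alters the ring itself, and it stays within the scatter: a 1.2-fold lower number from compound 2 to compound 3 (0.08 log units; within the scatter). The earlier step changed only the group carried on the ring nitrogen, whereas this one shows that, with carbamoyl kept, the five-membered and four-membered rings cannot be told apart in this read-out, even though the defined stereocentre of compound 2 is absent from compound 3. Nothing measured here offers a reason for this outcome.

As far as these compounds go, it remains open whether a carboxylic acid or a primary amine in place of the carbamoyl would shift the number on the four-membered ring. From the compounds shown here alone, compound 1 reads >= 186000 nM, which is a limit of the assay and not a number, so how 2-cyanophenyl behaves on the four-membered ring also remains open.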